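The source may report more compounds than this note shows. Statements on the series, on what has been measured and on what is new or still open speak of the compounds shown alone.

Values in an ADME assay on NIH3T3 cells (Mus musculus) for cytotoxicity; a lower number here means that less compound is needed, a higher number that more compound is needed for the effect:
- compound 1 `Cc1cccc(Oc2cccc(Cn3ccnc3)c2)c1`: 78700 nM
- compound 2 `Cc1cc(Oc2cccc(Cn3cnnc3)c2)cc(C)c1Cl`: > 100000 nM

Compound 2 gives > 100000 nM, which is a limit of the assay and not a number. It therefore has no exact position in the series, and the data so far show (the limit of > 100000 nM in this assay, at which 1 of the 2 values shown sits).

The next compound to be measured is compound 3 `Cc1nnc(Cc2cccc(Oc3cc(C)c(Cl)c(C)c3)c2)s1`. Its difference from compound 2 is 5-methyl-1,3,4-thiadiazol-2-yl in place of 4H-1,2,4-triazol-4-yl on a saturated chain carbon bound to an aromatic carbon. In words, 5-methyl-1,3,4-thiadiazol-2-yl stands in place of 4H-1,2,4-triazol-4-yl on a saturated chain carbon bound to an aromatic carbon.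

For the measured compounds named here, no step between measured compounds is available to size this change. Going by the values given here, the only numerical anchor is compound 1 at 78700 nM, so the expectation is loose. A modest move toward a lower number in this assay is expected, meaning less compound needed for the effect, and the estimated step is an at least 1.6-fold lower number from compound 2 to compound 3 (0.22 log units; that floor lies within the scatter). A second reading at the limit would not be a surprise.

Compound 3 is expected at 60000 nM, with an estimated range of 20000 nM to 100000 nM.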

Compound 3, half-maximal effective concentration: 3800 nM
The estimate for compound 3 lay 16-fold (1.20 log units) above the measured number, and the stated range ends above it.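

In this assay, 5-methyl-1,3,4-thiadiazol-2-yl in place of 4H-1,2,4-triazol-4-yl on a saturated chain carbon bound to an aromatic carbon gives an at least 26-fold lower number from compound 2 to compound 3 (1.42 log units; beyond the scatter). This shows that the group at this place can strongly shift how much compound is needed for the effect, even though the two groups match in hydrogen-bond donors, hydrogen-bond acceptors and net charge. Compound 2 reads > 100000 nM, which is a limit of the assay and not a number, so the printed step is a floor and its full size is unknown: the limit of > 100000 nM in this assay, at which 1 of the 3 values shown sits.

The change swaps the ring atoms and adds a methyl at the same time, so the compounds shown do not separate the contribution of the sulfur-containing ring from that of the methyl. Also open, as far as these compounds go, are how an unsubstituted 1,3,4-thiadiazol-2-yl or a carboxylic acid would read at this place, and whether the same exchange would have a similar effect on the core of compound 1, which differs from compound 2 in more than one place.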